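Sulfonyl aryl swaps on the piperidinyl ketone core

The source may hold more compounds than are shown below. What is called first, only, known or untested is meant among the compounds shown, and "the series" means these compounds.

Working notes on the series. The shared core of compound 1 `COc1ccc(S(=O)(=O)NCCN2CCC(CCC(=O)c3cc(Cl)c(N)cc3OC)CC2)cc1Cl` carries a sulfonamide whose sulfonyl sulfur bears a variable aryl group. Going by the values given here, in an assay on HEK293 cells for displacement of a labelled ligand from 5-hydroxytryptamine receptor 6 (Homo sapiens), with a stated time of 60 min, in the presence of a further agent that is not named here (on this read-out higher numbers stand for weaker inhibition and lower numbers for stronger inhibition), compound 1 gives 158 nM, the lowest of the three numbers so far. Compound 2 `COc1cc(N)c(Cl)cc1C(=O)CCC1CCN(CCNS(=O)(=O)c2ccc(N)c(Br)c2)CC1` gives 219 nM, and compound 3 `COc1cc(N)c(Cl)cc1C(=O)CCC1CCN(CCNS(=O)(=O)c2ccc(NC(C)=O)cc2)CC1` gives 834 nM. The step of a 1.4-fold higher number from compound 1 to compound 2 (0.14 log units; within the scatter) lies within the scatter, whereas a 5.3-fold higher number from compound 1 to compound 3 (0.72 log units; beyond the scatter) and a 3.8-fold higher number from compound 2 to compound 3 (0.58 log units; beyond the scatter) are both beyond it, so only the acetamidophenyl compound stands apart.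

Compound 4 `COc1cc(N)c(Cl)cc1C(=O)CCC1CCN(CCNS(=O)(=O)c2cc(Br)c(N)c(Br)c2)CC1` differs from compound 1 by 4-amino-3,5-dibromophenyl in place of 3-chloro-4-methoxyphenyl on a sulfonyl sulfur. Among the compounds with values here, the one measured step that bears on it is a 1.4-fold higher number from compound 1 to compound 2 (0.14 log units; within the scatter), where an amino-bromo aryl in place of the chloro-methoxy aryl left the number within the scatter. Within the data shown here, no measured pair shows what a second bromine on that ring does. On this basis compound 4 is expected to sit near compound 1 and compound 2, with a step of a 1.4-fold higher number from compound 1 to compound 4 (0.14 log units; within the scatter) that need not exceed the scatter. The estimate for compound 4 is 220 nM, with a range from 90 nM to 550 nM.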

Compound 4, inhibition constant: 140 nM
Compound 4: the middle estimate sits 1.6-fold (0.20 log units) above what was measured; the measured number falls inside the stated range.
By their numbers in this assay, from the lowest: compounds 4, 1 and 2 (each within the scatter of the next); then compound 3.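

Going by these compounds alone, a bromo in place of hydrogen on an aromatic carbon, the one change on this aryl group that the earlier compounds did not isolate, gives (a 1.6-fold lower number from compound 2 to compound 4 (0.19 log units; within the scatter)), so in this assay the second bromine leaves the two numbers within the scatter of each other. Within the data shown here, the sulfonyl sulfur also tolerates 4-amino-3,5-dibromophenyl in place of 3-chloro-4-methoxyphenyl (a 1.1-fold lower number from compound 1 to compound 4 (0.05 log units; within the scatter)), while the step from the acetamide (a 6.0-fold lower number from compound 3 to compound 4 (0.78 log units; beyond the scatter)) is beyond the scatter, leaving 4-acetamidophenyl as the only aryl group here that stands apart. No supporting evidence accounts for these numbers.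

Still open, from the compounds shown here alone, is what a 4-aminophenyl group carrying no halogen gives on the sulfonyl sulfur. Also open, going by these compounds, is whether chlorine or methyl in place of the two bromines, or a pyridine ring in place of the phenyl, keeps the number in this range.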